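The source may hold more compounds than are shown below. What is called first, only, known or untested is meant among the compounds shown, and "the series" means these compounds.

In a functional assay on A549 cells (Homo sapiens) for inhibition, read by MTT assay, with a stated time of 72 h (a higher number here means a weaker inhibitor, a lower number a stronger inhibitor), compound 1 (`C=C(Cl)C(=O)Nc1cc(Nc2nc3c(c(-c4cn(C)c5ccc(F)cc45)n2)CSCC3)c(OC)cc1N(C)CCN(C)C`) gives 864 nM, compound 2 (`CC/C=C\C(=O)Nc1cc(Nc2nc3c(c(-c4cn(C)c5ccc(F)cc45)n2)CSCC3)c(OC)cc1N(C)CCN(C)C`) gives 1450 nM and compound 3 (`C=C(Cl)C(=O)Nc1cc(Nc2nc3c(c(-c4cn(C)c5ccccc45)n2)CSCC3)c(OC)cc1N(C)CCN(C)C`) gives 716 nM. Compound 3 stands level with compound 1 within the scatter, while the number for compound 2 lies beyond the scatter from that of compound 3. Compound 4 (`CCC/C=C\C(=O)Nc1cc(Nc2nc3c(c(-c4cn(C)c5ccccc45)n2)CSCC3)c(OC)cc1N(C)CCN(C)C`) has pent-1-en-1-yl in place of 1-chloroethenyl on a carbonyl carbon. The closest measured change is a 1.7-fold higher number from compound 1 to compound 2 (0.22 log units; within the scatter), where but-1-en-1-yl replaces the same group. The change at the aromatic carbon, a 1.2-fold lower number from compound 1 to compound 3 (0.08 log units; within the scatter), bears on it only slightly. A small rise in this assay is therefore expected, possibly no larger than the scatter. The expected change is a 1.7-fold higher number from compound 3 to compound 4 (0.22 log units; within the scatter). For compound 4 the estimate is 1200 nM, with an expected range of 650 nM to 2200 nM.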

Compound 4, half-maximal inhibitory concentration: 571 nM
The estimate for compound 4 lay 2.1-fold (0.32 log units) above the measured number, outside the stated range (below it).
By their numbers in this assay, from the lowest: compounds 4, 3, 1 and 2 (each within the scatter of the next, the first and the last beyond it).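

In this assay, replacing 1-chloroethenyl with pent-1-en-1-yl on the carbonyl carbon gives a 1.3-fold lower number from compound 3 to compound 4 (0.10 log units; within the scatter), so on the core lacking the fluoro group, this site accepts a chlorine-free chain of 5 carbons with no change beyond the scatter. Both chain replacements at this position, but-1-en-1-yl with the fluoro group and pent-1-en-1-yl without it, now stay within the scatter. Nothing available explains this result. From the compounds shown here alone, whether a longer chain such as hept-1-en-1-yl, or a chain ending in a dimethylamino group, would also stay within the scatter remains open.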